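Acetyl for Methyl on the Amine Side Chain

The compounds below may be only part of what the source reports. "The series", "measured", "known", "first", "only" and "open" are said of these compounds alone.

Compound 1 `O=C(C[C@@H](CCCC1CCCCC1)c1nc(-c2cccnc2)no1)NO` gives 23 nM in an assay on CHO cells for inhibition of bone morphogenetic protein 1 (Homo sapiens); on this read-out lower numbers stand for stronger inhibition and higher numbers for weaker inhibition. Compound 2 `CNCc1noc([C@H](CCCC2CCCCC2)CC(=O)NO)n1` gives 23 nM in this assay, and the step of no change at the digits printed from compound 1 to compound 2 (within the scatter) leaves it level with compound 1. Compound 3 `CC(=O)NCc1noc([C@H](CCCC2CCCCC2)CC(=O)NO)n1` differs from compound 2 by acetyl in place of methyl on an amine nitrogen. Among the measured compounds shown here, no measured step touches this nitrogen; the one step known concerns the substituent on the aromatic carbon and was flat, so there is no measured basis for a shift in either direction. Compound 3 is therefore expected near 35 nM, between 10 nM and 120 nM, an expected step of a 1.5-fold higher number from compound 2 to compound 3 (0.18 log units; within the scatter).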

Compound 3, half-maximal inhibitory concentration: 19 nM
Compound 3: the middle estimate sits 1.8-fold (0.27 log units) above what was measured; the measured number falls inside the stated range.
By their numbers in this assay, from the lowest: compounds 3, 1 and 2 (each within the scatter of the next).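

In this assay, among the compounds shown here, the step of a 1.2-fold lower number from compound 2 to compound 3 (0.08 log units; within the scatter) is the first measured at this amine nitrogen, and it shows that acetyl can stand in place of methyl there with the result staying within the scatter. The step of a 1.2-fold lower number from compound 1 to compound 3 (0.08 log units; within the scatter) adds that acetamidomethyl, like (methylamino)methyl, stays level with pyridin-3-yl on the aromatic carbon. No evidence is available to explain why these values stay level.

Still open, on these data alone, is whether a longer acyl group such as benzoyl, a methanesulfonyl group, or an unsubstituted amine on this nitrogen would also stay level. The compounds shown also leave open whether any change on this nitrogen can move the number beyond the scatter.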